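The source may hold more compounds than are shown below. What is called first, only, known or untested is meant among the compounds shown, and "the series" means these compounds.

Measured so far in a functional assay on HCT-116 cells (Homo sapiens) for antiproliferative activity, read by WST assay, with a stated time of 72 h; on this read-out lower numbers stand for stronger inhibition of growth and higher numbers for weaker inhibition of growth:
- compound 1 `N#Cc1ccc(CN[C@H]2[C@@H]3CN(c4ncc(C(=O)NO)cn4)C[C@@H]32)cc1`: 270 nM
- compound 2 `O=C(NO)c1cnc(N2C[C@@H]3[C@H](C2)[C@H]3NCc2ccc(Br)cc2)nc1`: 250 nM
- compound 3 `O=C(NO)c1cnc(N2C[C@@H]3[C@H](C2)[C@H]3NCc2ccc(C(F)(F)F)cc2)nc1`: 700 nM

Compound 3, at 700 nM, has the highest number of the three, which makes it the weakest growth inhibitor of this small set. Compound 4 `O=C(NO)c1cnc(N2C[C@@H]3[C@H](C2)[C@H]3NCc2ccc(Oc3ccccc3)cc2)nc1` changes one group of compound 3: phenoxy in place of trifluoromethyl on an aromatic carbon, para to a large group (phenoxy in place of trifluoromethyl on an aromatic carbon).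

Among the measured compounds shown here, three measured steps bear on this change, all made at that same place. The first is a 1.1-fold lower number from compound 1 to compound 2 (0.03 log units; within the scatter). The other two are modest: a 2.6-fold higher number from compound 1 to compound 3 (0.41 log units; beyond the scatter) and a 2.8-fold higher number from compound 2 to compound 3 (0.45 log units; beyond the scatter). Swapping this group has so far moved this assay only a little. For the measured compounds named here, no measured compound carries phenoxy, so these steps are only a loose guide.

Since compound 3 sits at the top of the range, a modest move toward lower numbers is expected. The expected change is a 2.2-fold lower number from compound 3 to compound 4 (0.34 log units; beyond the scatter). For compound 4 the estimated value is 320 nM, with an expected range from 110 nM to 900 nM.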

Compound 4, concentration for 50% growth inhibition: 120 nM
The estimate for compound 4 lay 2.7-fold (0.43 log units) above the measured number; the measured number falls inside the stated range.
By their numbers in this assay, from the lowest: compound 4; then compounds 2 and 1 (each within the scatter of the next); then compound 3.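

In this assay phenoxy, which brings a second six-membered aromatic ring to this position, gives the lowest number yet, with a 5.8-fold lower number from compound 3 to compound 4 (0.77 log units; beyond the scatter) and, against the other two groups, a 2.1-fold lower number from compound 2 to compound 4 (0.32 log units; beyond the scatter) and a 2.3-fold lower number from compound 1 to compound 4 (0.35 log units; beyond the scatter). This makes compound 4 the strongest growth inhibitor of the four and shows that this position accepts a group with more heavy atoms than trifluoromethyl and a ring of its own, a change that takes the number below the level shared by compounds 1 and 2. Nothing available explains why phenoxy does better here.

Going by these compounds, it remains open whether the gain comes from the ring or from the oxygen that links it, and a directly attached phenyl or a benzyloxy group would help to separate the two. The core is the same in all four compounds, so it is also unknown whether the gain would hold with a different core.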